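Rearranging an Ether Side Chain and Solubility

The source may report more compounds than this note shows. Statements on the series, on what has been measured and on what is new or still open speak of the compounds shown alone.

Measured so far:
Compound 1 `CCCCCOCc1cc(=O)c2ccccc2[nH]1`: in a physicochemical assay for solubility, read by HPLC, at pH 7.4 (on this read-out higher numbers stand for higher solubility and lower numbers for lower solubility), compound 1 gives > 200000 nM, which is a limit of the assay and not a number.
Compound 2 `CCOCCCCc1cc(=O)c2ccccc2[nH]1`: in this assay compound 2 gives > 200000 nM, again a limit rather than a number.
Compound 3 `CCCCCOCc1[nH]c2ccc([N+](=O)[O-])cc2c(=O)c1C(=O)O`: in this assay compound 3 gives 50000 nM.

Compounds 1 and 2 both sit at the limit of > 200000 nM in this assay, at which 2 of the 3 values shown sit, so the change between them, (3-ethoxypropyl in place of pentyloxy on a saturated chain carbon bound to an aromatic carbon), yields a step that the two limits leave unreadable from compound 1 to compound 2. Compound 3 carries a different core; the difference between the core of compound 1 and the core of compound 3 is not broken down here. Compound 4 `CCOCCCCc1[nH]c2ccc([N+](=O)[O-])cc2c(=O)c1C(=O)O` is the not yet measured partner of compound 3, and the change is 3-ethoxypropyl in place of pentyloxy on a saturated chain carbon bound to an aromatic carbon, the same change as from compound 1 to compound 2, at the same place. Because compound 1 and compound 2 both reach (the limit of > 200000 nM in this assay, at which 2 of the 3 values shown sit), the earlier step gives no readable size, and the two chains hold the same atoms joined differently. A small step is therefore expected, no change at the digits printed from compound 3 to compound 4 (within the scatter). Compound 4 is expected to give 50000 nM, most likely between 20000 nM and 125000 nM.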

Compound 4, solubility: 50000 nM
Estimate against measurement, compound 4: no gap at the digits printed; the range from low to high includes it.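

On the core of compound 3, putting 3-ethoxypropyl in place of pentyloxy on a saturated chain carbon bound to an aromatic carbon gives no change at the digits printed from compound 3 to compound 4 (within the scatter) in this assay, so on this core the two chains, made of the same atoms joined differently, read alike. This is the only readable size for the change, and it cannot be compared with the core of compound 1, where the step stays unreadable because compound 1 and compound 2 both give a limit of the assay and not a number: the limit of > 200000 nM in this assay, at which 2 of the 4 values shown sit. The two cores therefore show no conflict, but they do not show that the change behaves alike on both, and one readable pair sets no rule for any other core.

Still open, from the compounds shown here alone, is whether a chain carrying an amine, or a longer ether chain, would read differently on the core of compound 3. Also open is how much the nitro group and the carboxylic acid of compound 3 each contribute to its value, as the two appear together in the compounds shown.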